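Second hydroxymethyl on the urea substituent of compound 3

The compounds below may be only part of what the source reports. "The series", "measured", "known", "first", "only" and "open" are said of these compounds alone.

Measured compounds:
compound 1, `Cc1ccc(CN2CCC(CCN(Cc3ccc(-c4ccc(F)cc4)cc3)C(=O)NC(C)C)CC2)cc1`, 6.42;
compound 2, `CC(=O)OCC(C)(C)NC(=O)N(CCC1CCN(Cc2ccc(C)cc2)CC1)Cc1ccc(-c2ccc(F)cc2)cc1`, 6.39;
compound 3, `Cc1ccc(CN2CCC(CCN(Cc3ccc(-c4ccc(F)cc4)cc3)C(=O)NC(C)(C)CO)CC2)cc1`, 7.39.

These values come from an in vitro functional assay on HEK293 cells for antagonist activity at melanin-concentrating hormone receptor 1 (Homo sapiens), read by GTPgammaS binding, with a stated time of 45 min; a lower number here means a less potent compound, a higher number a more potent compound, by a factor of ten per unit of this negative logarithm. Compound 3 stands highest of the three, its nearest neighbour compound 1 lying a number 0.97 log units higher from compound 1 to compound 3 (beyond the scatter) and compound 2 lying a number 1.00 log units higher from compound 2 to compound 3 (beyond the scatter). Compound 2 and compound 1 differ by a number 0.03 log units lower from compound 1 to compound 2 (within the scatter). Compound 4, `CCC(CO)(CO)NC(=O)N(CCC1CCN(Cc2ccc(C)cc2)CC1)Cc1ccc(-c2ccc(F)cc2)cc1`, differs from compound 3 by 1,1-bis(hydroxymethyl)propyl in place of 1-(hydroxymethyl)-1-methylethyl on an amide-type nitrogen. Within the data shown here, no measured step covers this change directly; the steps that bear on it show that adding a hydroxymethyl to this carbon mattered, while adding acetoxymethyl did not. A free hydroxyl is retained here, so the expected step is a number 0.09 log units lower from compound 3 to compound 4 (within the scatter), small in either direction. Compound 4 is estimated at 7.3, between 6.7 and 7.9.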

Compound 4, negative logarithm of the antagonist equilibrium constant: 6.54
Estimate against measurement, compound 4: 0.76 log units above; measured number outside the range, below it.
By their numbers in this assay, from the lowest: compounds 2, 1 and 4 (each within the scatter of the next); then compound 3.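

In this assay, a free hydroxyl on this carbon did not by itself keep the value of compound 3 , since 1,1-bis(hydroxymethyl)propyl gives a number 0.85 log units lower from compound 3 to compound 4 (beyond the scatter). Compound 4 cannot be told apart from the compounds without a free hydroxyl, with a number 0.12 log units higher from compound 1 to compound 4 (within the scatter) and a number 0.15 log units higher from compound 2 to compound 4 (within the scatter). Nothing available explains this.

Because the second hydroxymethyl and the ethyl arrive together, the compounds shown leave open which of them accounts for the step. Also open, from the compounds shown here alone, is how an amine or a carboxylic acid in place of the hydroxyl would read.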